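Thiourea series: aryl swap on the amide-type nitrogen

The source may report more compounds than this note shows. Statements on the series, on what has been measured and on what is new or still open speak of the compounds shown alone.

For the measured compounds named here, compound 1 `FC(F)(F)c1cccc(NC(=S)Nc2ccc(Cl)cc2)c1` gives 10000 nM in an ADME assay on BHK cells (Mesocricetus auratus) for cytotoxicity, read by MTT assay, with a stated time of 96 h (on this read-out lower numbers stand for higher toxicity in this test and higher numbers for lower toxicity in this test), the highest of the two numbers measured so far. Compound 2 `N#Cc1ccc(NC(=S)Nc2cccc(C(F)(F)F)c2)cc1` gives 9500 nM, and the step of a 1.1-fold lower number from compound 1 to compound 2 (0.02 log units; within the scatter) changed the number little. Compound 3 `Fc1cccc(NC(=S)Nc2cccc(C(F)(F)F)c2)c1` is unmeasured and differs from compound 1 in that (3-fluorophenyl in place of 4-chlorophenyl on an amide-type nitrogen). Going by the values given here, no measured step touches this ring position, and the one step known, a 1.1-fold lower number from compound 1 to compound 2 (0.02 log units; within the scatter), stayed within the scatter, so no shift beyond the scatter is expected in this assay. The step of no change at the digits printed from compound 1 to compound 3 (within the scatter) is the estimated one. For compound 3 the expected value is 10000 nM, with a range from 4000 nM to 25000 nM.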

Compound 3, half-maximal cytotoxic concentration: 9400 nM
Estimate against measurement, compound 3: 1.1-fold (0.03 log units) above; the range from low to high includes it.
By their numbers in this assay, from the lowest: compounds 3, 2 and 1 (each within the scatter of the next).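

In this assay, the step to 3-fluorophenyl on the amide-type nitrogen gives a 1.1-fold lower number from compound 1 to compound 3 (0.03 log units; within the scatter), so a second replacement of 4-chlorophenyl also stays within the scatter. This step swaps the halogen and also its place on the ring, and even this double alteration stays within the scatter. No measurement shown offers an explanation for this result.

The separate contributions of halogen identity and ring place remain unresolved. On these data alone, how an amine or a carboxylic acid on this ring would read in this assay stays open.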